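Fluoro for nitro on the aniline of compound 3

A few compounds are considered here, and "the series" means these few. Any claim that something is new, unique, unknown or untested is made for them only; others in the source may bear on it.

The series rests on a shared core carrying an aniline and a benzothiazole amine. Compound 1 `Cc1cnc(Nc2ccc(S(C)(=O)=O)cc2)nc1Nc1nc2ccc(Cl)cc2s1` gives 5900 nM in a functional assay on MDA-MB-231 cells (Homo sapiens) for antiproliferative activity, read by MTT assay, with a stated time of 48 h; a lower number here means a stronger inhibitor, a higher number a weaker inhibitor. Compound 2 `NS(=O)(=O)c1ccc(Nc2ncc(F)c(Nc3nc4ccccc4s3)n2)cc1` gives 22600 nM in this assay. Compound 3 `Cc1cnc(Nc2ccc([N+](=O)[O-])cc2)nc1Nc1nc2ccccc2s1` gives 22500 nM in this assay, the second highest of the three numbers; its value and that of compound 2 lie within the usual scatter, while compound 1 sits beyond it with the lower number. Compound 4 `Cc1cnc(Nc2ccc(F)cc2)nc1Nc1nc2ccccc2s1` differs from compound 3 by fluoro in place of nitro on an aromatic carbon. Going by the values given here, no measured pair shows this change, so the step from nitro to fluoro is expected to stay within the scatter, with no clear direction: the expected step is a 1.1-fold higher number from compound 3 to compound 4 (0.05 log units; within the scatter). Compound 4 is therefore estimated at 25000 nM, within 8000 nM to 80000 nM.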

Compound 4, half-maximal inhibitory concentration: > 50000 nM
Compound 4 ended at the assay's limit; the forecaster's own chance of this, stated with the estimate: 10%; at least 2.0-fold (0.30 log units) between middle value and limit.
By their numbers in this assay, from the lowest: compound 1; then compounds 3 and 2 (each within the scatter of the next). At a limit, above all of these: compound 4.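

Compound 4 gives > 50000 nM in this assay, a value that is a limit of the assay and not a number: the limit of > 50000 nM in this assay, at which 1 of the 4 values shown sits. Fluoro in place of nitro, on this aromatic carbon para to a large group, is the only single change shown, and it gives an at least 2.2-fold higher number from compound 3 to compound 4 (0.34 log units; beyond the scatter). This place on the aniline is therefore not indifferent to the group it carries.

As far as these compounds go, how far the step reaches stays open with a limit at one end. So does whether an amine or a carboxylic acid on this carbon would give a lower number than nitro.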